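A few compounds are considered here, and "the series" means these few. Any claim that something is new, unique, unknown or untested is made for them only; others in the source may bear on it.

In a functional assay on A549 cells (Homo sapiens) for cytotoxicity (a lower number here means a stronger inhibitor, a higher number a weaker inhibitor), compound 1 `Cc1ccc(C2CN(S(=O)(=O)c3ccccc3)C(=O)N2)cc1` gives > 316000 nM, which is a limit of the assay and not a number. Compound 2 `Cc1ccc(C2CN(S(=O)(=O)c3ccc(Cl)cc3)C(=O)N2)cc1` gives 158000 nM. Among the compounds with values here, compound 3 `Cc1ccc(S(=O)(=O)N2CC(c3ccccc3)NC2=O)cc1` gives 12500 nM, the lowest number so far and beyond the scatter from compound 2.

Compound 4 `Cc1ccc(C2CN(S(=O)(=O)c3ccc(C)cc3)C(=O)N2)cc1` is compound 3 with methyl in place of hydrogen on an aromatic carbon, phenyl to 4-methylphenyl (methyl in place of hydrogen on an aromatic carbon).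

Within the data shown here, no measured step covers this change. Among the measured compounds shown here, the one step available, an at least 2.0-fold lower number from compound 1 to compound 2 (0.30 log units; that floor lies within the scatter), is a chloro change at another place, and its floor lies within the scatter, so it says little here. The better guide is that compound 2, which already carries the 4-methylphenyl group, sits at 158000 nM, although it also differs from compound 3 elsewhere. A move to a higher number is therefore expected, probably smaller than the whole gap between those two values.

The expected change is a 4.0-fold higher number from compound 3 to compound 4 (0.60 log units; beyond the scatter). For compound 4 the estimated value is 50000 nM, with an expected range of 12000 nM to 200000 nM.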

Compound 4, half-maximal inhibitory concentration: > 302000 nM
Compound 4: no number, only a limit; the forecaster's own chance of this, stated with the estimate: 10%; middle value at least 6.0-fold (0.78 log units) from the limit.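

In this assay, phenyl to 4-methylphenyl on compound 3 proves to be a large step, an at least 24-fold higher number from compound 3 to compound 4 (1.38 log units; beyond the scatter), so this position tolerates even a single added methyl poorly. Compound 4 gives > 302000 nM, which is a limit of the assay and not a number. Methyl in place of chloro gives an at least 1.9-fold higher number from compound 2 to compound 4 (0.28 log units; that floor lies within the scatter), so that step says little, and the step from compound 1 to compound 4 cannot be read.

From the compounds shown here alone, it remains open whether this loss is specific to methyl or follows from any group on an aromatic carbon at this place, which a methoxy, a hydroxyl or an amine there would test. Going by these compounds, the true size of the step from compound 3 also stays unknown, since only its floor can be read.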